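Ring substitution on the shared core: nitro analogue

The source may report more compounds than this note shows. Statements on the series, on what has been measured and on what is new or still open speak of the compounds shown alone.

Compound 1 `O=c1[nH]c2ccccc2oc1=O` gives 42000 nM in a functional assay with Rattus norvegicus as the target (on this read-out lower numbers stand for stronger inhibition and higher numbers for weaker inhibition), and stands at the high end of the three numbers shown, all of which sit within the scatter of one another. Compound 2 `COc1ccc2[nH]c(=O)c(=O)oc2c1` gives 28000 nM and compound 3 `Cc1ccc2[nH]c(=O)c(=O)oc2c1` gives 32000 nM; the steps are a 1.5-fold lower number from compound 1 to compound 2 (0.18 log units; within the scatter) and a 1.3-fold lower number from compound 1 to compound 3 (0.12 log units; within the scatter). Compound 4 `O=c1[nH]c2cc([N+](=O)[O-])ccc2oc1=O` differs from compound 1 by nitro in place of hydrogen on an aromatic carbon. Among the compounds with values here, the two measured substitutions on an aromatic carbon of the shared core, methoxy and methyl, both stayed within the scatter, so no step beyond the scatter is expected in this assay for the nitro change either, and no measured step settles its direction. Compound 4 is therefore expected at 35000 nM, range 12000 nM to 100000 nM, an expected 1.2-fold lower number from compound 1 to compound 4 (0.08 log units; within the scatter).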

Compound 4, half-maximal inhibitory concentration: 800 nM
Estimate against measurement, compound 4: 44-fold (1.64 log units) above; measured number below the stated range.
By their numbers in this assay, from the lowest: compound 4; then compounds 2, 3 and 1 (each within the scatter of the next).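

In this assay, nitro in place of hydrogen on an aromatic carbon gives a 53-fold lower number from compound 1 to compound 4 (1.72 log units; beyond the scatter), a large step, whereas the methoxy and methyl changes stayed within the scatter. Substitution on this ring of the shared core can therefore move the number strongly. Nothing available bears on why this step occurs.

Compound 4 carries its group on a different aromatic carbon from compounds 2 and 3, so the compounds shown do not separate the effect of the group from that of its place. As far as these compounds go, whether an amine or a nitrile on the same carbon would give a similar step remains open.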